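Swapping the aryl group on a shared thiazole-amine core

The compounds below may be only part of what the source reports. "The series", "measured", "known", "first", "only" and "open" are said of these compounds alone.

Compound 2 `CN(C)c1cccc(Nc2nc3c(s2)CCCCc2nc(NC(=O)C(C)(C)C)sc2-3)c1`: 5200 nM
Compound 1 `CN(C)c1ccc(Cl)cc1Nc1nc2c(s1)CCCCc1nc(NC(=O)C(C)(C)C)sc1-2`: 2100 nM

In an assay on cells (Epithelial cell) with Cystic fibrosis transmembrane conductance regulator variant F508del (Homo sapiens) as the target, read by fluorescence, with a stated time of 20 h (a lower number here means a stronger inhibitor, a higher number a weaker inhibitor), compound 2 gives the highest of the two numbers shown, with compound 1 the nearest at 2100 nM. Compound 3 `COc1ccc([N+](=O)[O-])cc1Nc1nc2c(s1)CCCCc1nc(NC(=O)C(C)(C)C)sc1-2` differs from compound 2 only in 2-methoxy-5-nitrophenyl in place of 3-(dimethylamino)phenyl on a nitrogen on an aromatic ring. Among the compounds with values here, the one step that bears on this position is a 2.5-fold higher number from compound 1 to compound 2 (0.39 log units; beyond the scatter), showing that exchanging this aryl group moves the number modestly. Because that step a 2.5-fold higher number from compound 1 to compound 2 (0.39 log units; beyond the scatter) was small, compound 3 is expected to land near compound 2, with a 1.5-fold lower number from compound 2 to compound 3 (0.17 log units; within the scatter) as the estimated step. The estimate for compound 3 is 3500 nM, ranging from 1200 nM to 10000 nM.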

Compound 3, half-maximal inhibitory concentration: 900 nM
Compound 3: middle estimate off by 3.9-fold (0.59 log units), on the high side; the whole stated range lies above it.
By their numbers in this assay, from the lowest: compound 3; then compound 1; then compound 2.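

In this assay, the aryl group on this nitrogen can push the number down as well as up: 2-methoxy-5-nitrophenyl in place of 3-(dimethylamino)phenyl gives a 5.8-fold lower number from compound 2 to compound 3 (0.76 log units; beyond the scatter), and in place of 5-chloro-2-(dimethylamino)phenyl it gives a 2.3-fold lower number from compound 1 to compound 3 (0.37 log units; beyond the scatter). Compound 3 carries no dimethylamino group yet has the lowest number of the three, so that group is not required for a low number here. Nothing on hand explains this difference. The compounds shown do not separate the methoxy from the nitro group, so which of them goes with the lower number stays open. Also open, on these data alone, is what a nitrile or a carboxylic acid would do in place of the nitro group.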